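Morpholine to Cyclopentylamine on a Shared Amide Carbon

The source may hold more compounds than are shown below. What is called first, only, known or untested is meant among the compounds shown, and "the series" means these compounds.

Three compounds built on one shared core have so far been run in a functional assay on PC-3 cells (Homo sapiens) for inhibition, read by sulforhodamine B assay, with a stated time of 72 h; a higher number here means a weaker inhibitor, a lower number a stronger inhibitor. Compound 1 `CCOC(=O)Nc1sc(-c2ccc(Cl)cc2)c(-c2ccc(Cl)cc2)c1C(=O)NC1CC1` gives 27600 nM. Compound 2 `Nc1sc(-c2ccc(Cl)cc2)c(-c2ccc(Cl)cc2)c1C(=O)N1CCOCC1` gives 11700 nM, and compound 3 `CC(=O)Nc1sc(-c2ccc(Cl)cc2)c(-c2ccc(Cl)cc2)c1C(=O)N1CCCCC1` gives 10300 nM. Among these three numbers compound 2 stands second highest: its number sits within the scatter of compound 3, while it lies below compound 1 by more than the scatter. Compound 4 `Nc1sc(-c2ccc(Cl)cc2)c(-c2ccc(Cl)cc2)c1C(=O)NC1CCCC1` has not yet been measured. It differs from compound 2 in one place: cyclopentylamino in place of morpholin-4-yl on a carbonyl carbon. Within the data shown here, no measured pair differs by this change alone, so no direction is known from the data. The step from compound 2 to compound 4 is expected to be small, a 1.2-fold higher number from compound 2 to compound 4 (0.08 log units; within the scatter), hardly beyond the scatter. Compound 4 is therefore estimated at 14000 nM, with a range from 5000 nM to 40000 nM.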

Compound 4, half-maximal inhibitory concentration: 21200 nM
The estimate for compound 4 lay 1.5-fold (0.18 log units) below the measured number, and the stated range covers the measured number.
By their numbers in this assay, from the lowest: compounds 3, 2, 4 and 1 (each within the scatter of the next, the first and the last beyond it).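

Among these compounds, this step is the first direct reading of a change at this carbonyl carbon, and a 1.8-fold higher number from compound 2 to compound 4 (0.26 log units; within the scatter) shows that in this assay, cyclopentylamino and morpholin-4-yl cannot be told apart on the shared core. The swap removes the ring oxygen and brings in the amide hydrogen, yet the two numbers stay within the scatter of each other. No measurement at hand accounts for this result. Still open, as far as these compounds go, is whether a dimethylamino group, a longer alkyl chain or a carboxylic acid on this carbonyl carbon would separate from these two.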